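The source may report more compounds than this note shows. Statements on the series, on what has been measured and on what is new or still open speak of the compounds shown alone.

Working notes on the series. Compound 1 `CC1CCCc2c1nc(N)c(C#N)c2-c1cccn1C`, built on a core of its own, gives 69200 nM in a functional assay on MDA-MB-231 cells (Homo sapiens) for inhibition, read by sulforhodamine B assay, with a stated time of 48 h; on this read-out higher numbers stand for weaker inhibition of growth and lower numbers for stronger inhibition of growth. Compound 2 `COc1ccc(-c2cc(-c3cccn3C)c(C#N)c(=O)[nH]2)cc1OC` is reported in this assay only as a limit, > 100000 nM. Compound 3 `Cn1cccc1-c1cc(-c2cccs2)[nH]c(=O)c1C#N` likewise returns only a limit in this assay, > 100000 nM. Compound 3 thus stands at the limit of > 100000 nM in this assay, at which 2 of the 3 values shown sit, rather than at a measured number, and it cannot be ordered against compound 2; only compound 1 is given as a number. Compound 4 `Cn1cccc1-c1cc(-c2ccccc2)[nH]c(=O)c1C#N` has not yet been measured. It differs from compound 3 by phenyl in place of thiophen-2-yl on an aromatic carbon, with the rest of the shared core unchanged. Going by the values given here, no measured pair in the set maps this exchange, so no step size is known from the data. Given that compound 3 is reported only as a limit, the expectation for compound 4 is no change beyond the usual scatter, and the step is estimated as a step that the limit leaves unreadable from compound 3 to compound 4. The estimate for compound 4 in this assay is 120000 nM, with a range from 40000 nM to 400000 nM, and with a fair chance that again only a limit is reported.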

Compound 4, concentration for 50% growth inhibition: 83200 nM
Compound 4: the middle estimate sits 1.4-fold (0.16 log units) above what was measured; low and high end bracket the measured number.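

In this assay, the exchange of thiophen-2-yl for phenyl, on the aromatic carbon next to the ring nitrogen, gives an at least 1.2-fold lower number from compound 3 to compound 4 (0.07 log units; that floor lies within the scatter). Going by these compounds alone, compound 4 carries the only measured number among the compounds that share this core, so this position can hold an unsubstituted phenyl and still give a value, but the floor of the step does not establish a real difference from thiophen-2-yl. Compound 3 is reported only as a limit, so the full size of the step cannot be read, and such limits make up much of the set: the limit of > 100000 nM in this assay, at which 2 of the 4 values shown sit.

From the compounds shown here alone, whether an amine or a carboxylic acid on the phenyl ring would move the number remains open. Going by these compounds, it is also open how a saturated alkyl chain such as butyl would fare at this position in place of an aromatic ring.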